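Benzyl ester extension of the glycine amide in a purine series

The source may report more compounds than this note shows. Statements on the series, on what has been measured and on what is new or still open speak of the compounds shown alone.

Measured compounds
Compound 1: `O=C(CN(c1nc(Cl)nc2[nH]cnc12)C1CC1)NCC(=O)OCc1ccccc1`; 27.2%
Compound 2: `CC[C@H](C)[C@H](NC(=O)CN(c1nc(Cl)nc2[nH]cnc12)C1CC1)C(=O)O`; 27.4%

Both compounds were run in a functional assay on the whole organism (Tail, strain ICR) with Mus musculus as the target, in the tail flick test, with a stated time of 90 min, at a dose of 25 umol/kg by the oral route; a lower number here means a weaker effect, a higher number a stronger effect of the compound at the dose given. In this assay compound 1 gives 27.2%, and compound 2 gives 27.4%. The two numbers lie within the usual scatter of each other, so compound 1 and compound 2 sit together and nothing separates them; no direction of change between them can be read from the data.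

The next compound is compound 3, `O=C(CN(c1nc(Cl)nc2[nH]cnc12)C1CC1)N[C@@H](CCC(=O)OCc1ccccc1)C(=O)OCc1ccccc1`, still to be measured in this assay. Relative to compound 1 the change is 2-(benzyloxycarbonyl)ethyl in place of hydrogen on a saturated chain carbon bound to an amide-type nitrogen and a carbonyl carbon. No pair of compounds differing in one place has been measured, so there is no shown step on which to build. The two measured values sit together, and nothing in them points to a large move either way. The step from compound 1 to compound 3 is therefore expected to be small, a number 2.2 percentage points lower from compound 1 to compound 3 (within the scatter), not clearly beyond the scatter. For compound 3 the expected value is 25%, with a range from 10% to 45%.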

Compound 3, a percentage reported as activity, at one dose (the size of the read-out at that dose, not a potency): 50%
For compound 3 the middle estimate is 25 percentage points below the measured one, and the stated range ends below it.
By their numbers in this assay, from the lowest: compounds 1 and 2 (each within the scatter of the next); then compound 3.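

In this assay the saturated chain carbon bound to an amide-type nitrogen and a carbonyl carbon turns out to be a place where substitution moves the read-out: 2-(benzyloxycarbonyl)ethyl in place of hydrogen gives a number 22.8 percentage points higher from compound 1 to compound 3 (beyond the scatter) and is the only step shown in the series. The step is modest, but it shows that this carbon can carry a group of 12 heavy atoms, including one six-membered aromatic ring, without loss of the effect at the dose given. Nothing available on the compounds accounts for the step, so the reason for it stays unknown.

From the compounds shown here alone, it remains open which part of the group carries the step: a methyl or a plain ethyl on the same carbon, or a carboxylic acid in place of the benzyl ester at the end of the chain, would show whether the added chain alone is enough or the benzyl ester is needed. Whether a longer chain or an amine at that end shifts the number further, and whether the step holds at other doses and times, is also unsettled.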